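Removing the branching methyl from the amide side chain

A few compounds are considered here, and "the series" means these few. Any claim that something is new, unique, unknown or untested is made for them only; others in the source may bear on it.

Within the data shown here, compound 2 `CC(C)[C@H](C)NC(=O)c1ccc(C#Cc2cccc(F)c2)cn1` is one of two compounds measured in a functional assay on HEK293 cells for positive allosteric modulation of metabotropic glutamate receptor 5 (Rattus norvegicus), read by fluorescence and calcium flux (a higher number here means a larger maximal response, a lower number a smaller maximal response), and in this assay compound 2 gives 66.7%. Among the measured compounds shown here, its only measured neighbour is compound 1 `CC(C)[C@@H](C)NC(=O)c1ccc(C#Cc2cccc(F)c2)cn1`, which in this assay gives 69.3%. The step of a number 2.6 percentage points lower from compound 1 to compound 2 (within the scatter) lies within the scatter, and the pair is tied together by the fact that compounds 1 and 2 differ only in the configuration as drawn, so the two arrangements of the methyl at the stereocentre give much the same maximal response.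

Compound 3 `CC(C)CNC(=O)c1ccc(C#Cc2cccc(F)c2)cn1` has not yet been measured. It differs from compound 2 in one place: hydrogen in place of methyl on a saturated chain carbon bound to an amide-type nitrogen and a saturated chain carbon. With that methyl gone, the stereocentre at which compounds 1 and 2 differ no longer exists. For the measured compounds named here, the only measured step that bears on this is the one from compound 1 to compound 2, which was small. It is therefore expected that removing the methyl altogether gives a step of a number 3.7 percentage points lower from compound 2 to compound 3 (within the scatter), in no clear direction and likely within the scatter. Compound 3 is estimated to give 63% in this assay, with a range from 40% to 85%.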

Compound 3, largest response reached (reported as efficacy), in percent of the reference or control that the assay uses: 58.2%
Beside the measured number, compound 3's estimate is 4.8 percentage points above it, within the range that was stated.
By their numbers in this assay, from the lowest: compounds 3, 2 and 1 (each within the scatter of the next, the first and the last beyond it).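

In this assay, taking the methyl off the saturated chain carbon, which turns 1,2-dimethylpropyl into isobutyl, gives a number 8.5 percentage points lower from compound 2 to compound 3 (within the scatter), while the same change gives a number 11.1 percentage points lower from compound 1 to compound 3 (beyond the scatter). Where the earlier pair tested only the arrangement of the methyl, this change removes it, and the response does not collapse: in this assay compound 3 still gives 58.2%, so the branching methyl is not required for a substantial maximal response. Its removal costs at most a modest part of that response, and the difference between the two readings should not be taken as a real dependence on configuration, since one step falls within the scatter and the other only modestly beyond it, and the two starting compounds are a close pair whose link is this: the fact that compounds 1 and 2 differ only in the configuration as drawn.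

From the compounds shown here alone, it remains open whether an ethyl or a hydroxymethyl group on this carbon, or a longer chain in place of isobutyl, would raise or lower the maximal response. The maximal response also leaves open how the concentration needed to reach it shifts across these side chains.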